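The source may hold more compounds than are shown below. What is called first, only, known or untested is meant among the compounds shown, and "the series" means these compounds.

Measured in a functional assay on SEM cells (Homo sapiens) for cytotoxicity, with a stated time of 72 h; on this read-out lower numbers stand for an effect already at smaller amounts and higher numbers for an effect only at larger amounts of compound:

- Compound 1 `CCOC(=O)/C=C/c1cc(/C=C/[C@](C)(/C=C/c2ccc(OC)cc2)CCC=C(C)C)ccc1O`: > 36600 nM, a limit
- Compound 2 `COc1ccc(/C=C/[C@@](C)(/C=C/c2ccc(O)c(/C=C/C(=O)OC(C)(C)C)c2)CCC=C(C)C)cc1`: > 36600 nM, a limit
- Compound 3 `COc1ccc(/C=C/[C@@](C)(/C=C/c2ccc(O)c(/C=C/C(C)=O)c2)CCC=C(C)C)cc1`: 8670 nM

For the measured compounds named here, compound 3 holds the only actual number in this assay, and the other two compounds sit at the limit of > 36600 nM in this assay, at which 2 of the 3 values shown sit. Compound 4 `COc1ccc(/C=C/[C@@](C)(/C=C/c2ccc(O)cc2)CCC=C(C)C)cc1` has hydrogen in place of 2-acetylethenyl on an aromatic carbon, ortho to a hydroxy group (hydrogen in place of 2-acetylethenyl on an aromatic carbon).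

Going by the values given here, two measured steps bear on this change: an at least 4.2-fold lower number from compound 1 to compound 3 (0.62 log units; beyond the scatter) and an at least 4.2-fold lower number from compound 2 to compound 3 (0.62 log units; beyond the scatter). Among the compounds with values here, both alter only what sits on the carbonyl carbon, and no measured step removes the whole group. The step between the two esters is a step that the two limits leave unreadable from compound 1 to compound 2, so it adds no size. Compound 3, at 8670 nM, is the only readable reference, and a modest move towards a higher number is expected. This move may possibly end at the limit of the assay. The expected change is a 3.2-fold higher number from compound 3 to compound 4 (0.51 log units; beyond the scatter). For compound 4 the estimated value is 28000 nM, with an expected range of 11000 nM to 70000 nM.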

Compound 4, half-maximal effective concentration: > 36600 nM
Compound 4: only a limit was reported; the forecaster's own chance of this, stated with the estimate: 55%; middle value at least 1.3-fold (0.11 log units) away from the limit.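

Replacing the 2-acetylethenyl group with hydrogen on the aromatic carbon ortho to a hydroxy group gives an at least 4.2-fold higher number from compound 3 to compound 4 (0.62 log units; beyond the scatter) in this assay. The earlier steps shown here changed only what sits on the carbonyl carbon, whereas this one removes the whole group, and the effect seen with compound 3 does not remain at a readable level. The reported value of compound 4, > 36600 nM, is a limit, which places compound 4 with the two esters: the limit of > 36600 nM in this assay, at which 3 of the 4 values shown sit.

From the compounds shown here alone, the steps from compound 1 and compound 2 to compound 4 join two limits and cannot be read, so how far the esters differ from hydrogen at this position stays open. Going by these compounds, it is also open whether a carboxylic acid or an amide in place of the acetyl end would follow compound 3 or the esters.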